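Working notes: bromo in place of chloro

The source may hold more compounds than are shown below. What is called first, only, known or untested is meant among the compounds shown, and "the series" means these compounds.

Measured in a functional assay on L1210 cells (Mus musculus) for antiproliferative activity, read by cell counting, with a stated time of 2 days; a lower number here means a stronger inhibitor, a higher number a weaker inhibitor:
- compound 1 `COc1cc(C(=O)c2sc(N)nc2N)cc(OC)c1OC`: 48000 nM
- compound 2 `COc1ccc(C(=O)c2sc(N3CCCC3)nc2N)cc1`: > 200000 nM (a limit)
- compound 3 `Nc1nc(N2CCCC2)sc1C(=O)c1ccc(Cl)cc1`: > 200000 nM (a limit)

Compound 3 has no number in this assay, only the limit > 200000 nM. It shares that position with one other compound: the limit of > 200000 nM in this assay, at which 2 of the 3 values shown sit.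

Compound 4 `Nc1nc(N2CCCC2)sc1C(=O)c1ccc(Br)cc1` differs from compound 3 by one change: bromo in place of chloro on an aromatic carbon. This is bromo in place of chloro, para to a large group.

Going by the values given here, the one measured step at this place is a step that the two limits leave unreadable from compound 2 to compound 3. It offers no size to carry over, so no step beyond the usual scatter is expected, and compound 4 will most likely also be reported only as a limit in this assay.

The estimated value for compound 4 is 200000 nM, with an expected range from 90000 nM to 400000 nM.

The expected change is a number no higher from compound 3 to compound 4 (the limit leaves the size open).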

Compound 4, half-maximal inhibitory concentration: > 200000 nM
Compound 4: no number, only a limit; the forecaster's own chance of this, stated with the estimate: 75%; the middle value lies on the limit itself.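

Compound 2, compound 3 and compound 4 each give only a limit in this assay, so no step among them can be read: the limit of > 200000 nM in this assay, at which 3 of the 4 values shown sit.

Going by these compounds, whether bromo, chloro and methoxy on this aromatic carbon differ at all in this assay remains open.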